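The compounds below may be only part of what the source reports. "The series", "measured", "known", "first", "only" and "open" are said of these compounds alone.

In a functional assay on PC-3 cells (Homo sapiens) for cytotoxicity, read by MTT assay, with a stated time of 48 h (a higher number here means a weaker inhibitor, a lower number a stronger inhibitor), three compounds that share one core and differ in a single aromatic group have been measured. Compound 1 `CC1(C)CCC[C@]2(C)[C@@H](CC[C@@](C)(O)/C=C/c3cccc([N+](=O)[O-])c3)[C@](C)(O)CC[C@@H]12` gives 153 nM, compound 2 `CC1(C)CCC[C@]2(C)[C@@H](CC[C@@](C)(O)/C=C/c3ccc(Cl)nc3)[C@](C)(O)CC[C@@H]12` gives 275 nM, and compound 3 `Cc1cccc(C)c1/C=C/[C@](C)(O)CC[C@@H]1[C@@]2(C)CCCC(C)(C)[C@@H]2CC[C@@]1(C)O` gives 278 nM. Compound 2 thus stands level with the other two, within the usual scatter of repeated measurements.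

Compound 4 `CC1(C)CCC[C@]2(C)[C@@H](CC[C@@](C)(O)/C=C/c3ccc(F)cc3)[C@](C)(O)CC[C@@H]12` keeps the core and differs from compound 2 at that same place: 4-fluorophenyl in place of 6-chloropyridin-3-yl on a double-bonded chain carbon bound to a double-bonded chain carbon. In words, 4-fluorophenyl stands in place of 6-chloropyridin-3-yl on a double-bonded chain carbon bound to a double-bonded chain carbon.

Three measured changes at this place bear on it: a 1.8-fold higher number from compound 1 to compound 2 (0.25 log units; within the scatter), a 1.8-fold higher number from compound 1 to compound 3 (0.26 log units; within the scatter) and a 1.0-fold higher number from compound 2 to compound 3 (0.00 log units; within the scatter). All three stay within the scatter. Within the data shown here, none of the measured compounds carries 4-fluorophenyl, so this is a cautious extrapolation. No step beyond the scatter is expected in this assay, and the data give no firm direction. The expected change is a 1.3-fold lower number from compound 2 to compound 4 (0.10 log units; within the scatter). For compound 4 the estimated value is 220 nM, with an expected range from 100 nM to 480 nM.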

Compound 4, half-maximal inhibitory concentration: 82 nM
Compound 4: middle estimate off by 2.7-fold (0.43 log units), on the high side; measured number outside the range, below it.
By their numbers in this assay, from the lowest: compounds 4, 1, 2 and 3 (each within the scatter of the next, the first and the last beyond it).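

Among these compounds, at this place on the chain, the choice of aromatic group now makes a measurable difference in this assay: the earlier compounds stood level with one another, whereas a 3.4-fold lower number from compound 2 to compound 4 (0.53 log units; beyond the scatter) and a 3.4-fold lower number from compound 3 to compound 4 (0.53 log units; beyond the scatter) both lie beyond the scatter, although both steps are modest. The 3-nitrophenyl group does not fit that picture, since a 1.9-fold lower number from compound 1 to compound 4 (0.27 log units; within the scatter) stays within the scatter, so compound 4 and compound 1 stand level and neither can be called the most potent of the four. Nothing available explains why 4-fluorophenyl gives a lower number than 6-chloropyridin-3-yl or 2,6-dimethylphenyl.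

The compounds shown leave open whether the fluorine itself matters, which plain phenyl could test. They also leave open whether an aromatic ring is needed here at all, which cyclohexyl could test.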